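The compounds below may be only part of what the source reports. "The series", "measured", "known", "first", "only" and "open" are said of these compounds alone.

Compound 1 `Cc1ccc(C)c(-n2nncc2CN2C(=O)C3(C(C#N)=C(N)Oc4c(N)cc5nc6ccccc6nc5c43)c3ccccc32)c1`: > 50000 nM
Compound 2 `CCc1cccc(CC)c1-n1nncc1CN1C(=O)C2(C(C#N)=C(N)Oc3c(N)cc4nc5ccccc5nc4c32)c2ccccc21`: > 50000 nM

In an ADME assay on L02 cells (Homo sapiens) for antiproliferative activity, read by MTT assay, with a stated time of 48 h (on this read-out lower numbers stand for stronger inhibition and higher numbers for weaker inhibition), compound 1 gives only a limit, > 50000 nM. In this assay compound 2 likewise gives only a limit, > 50000 nM. Going by the values given here, compound 2 thus stands at the edge of the read-out, and the one further value shown is a limit as well, so no order between the two can be read. The step that the two limits leave unreadable from compound 1 to compound 2 is accordingly left unreadable by the two limits. Compound 3 `Cc1ccc(-n2nncc2CN2C(=O)C3(C(C#N)=C(N)Oc4c(N)cc5nc6ccccc6nc5c43)c3ccccc32)cc1Cl` differs from compound 2 by 3-chloro-4-methylphenyl in place of 2,6-diethylphenyl on an aromatic nitrogen. Among the compounds with values here, the only measured step alters the same aromatic-nitrogen substituent, and its size is not readable, since both values sit at the limit of > 50000 nM in this assay, at which 2 of the 2 values shown sit. One therefore expects no readable step in this assay either, the estimated step that the limit leaves unreadable from compound 2 to compound 3 lying within scatter. Compound 3 is estimated at 60000 nM, between 30000 nM and 200000 nM.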

Compound 3, half-maximal inhibitory concentration: > 50000 nM
Compound 3: only a limit was reported (the forecaster's own chance of this, stated with the estimate: 85%); the middle value lies beyond the limit too.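

In this assay compound 3 gives > 50000 nM, which is a limit and not a number. No step among compound 1, compound 2 and compound 3 can be read, since all sit at the same limit: the limit of > 50000 nM in this assay, at which 3 of the 3 values shown sit.

The compounds shown leave open whether the groups on the aromatic nitrogen differ at all in this assay.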